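A few compounds are considered here, and "the series" means these few. Any claim that something is new, unique, unknown or untested is made for them only; others in the source may bear on it.

Compound 1: `Nc1nc(N)c2c(-c3ccsc3)cn([C@@H]3O[C@H](CO)[C@@H](O)[C@H]3O)c2n1` — > 20000 nM
Compound 2: `CSc1ncnc2c1c(-c1ccccc1)cn2[C@@H]1O[C@H](CO)[C@@H](O)[C@H]1O` — > 20000 nM

Of the compounds shown here, two have been measured in a functional assay on HeLa S3 cells (Homo sapiens) for antiproliferative activity, read by XTT assay, with a stated time of 72 h; on this read-out lower numbers stand for stronger inhibition and higher numbers for weaker inhibition. Compound 1 `Nc1nc(N)c2c(-c3ccsc3)cn([C@@H]3O[C@H](CO)[C@@H](O)[C@H]3O)c2n1` gives only a limit in this assay, > 20000 nM. Compound 2 `CSc1ncnc2c1c(-c1ccccc1)cn2[C@@H]1O[C@H](CO)[C@@H](O)[C@H]1O` likewise gives only a limit in this assay, > 20000 nM. Both results sit at the limit of > 20000 nM in this assay, at which 2 of the 2 values shown sit, so no numbered value separates them and nothing can be said of their order. Among the compounds with values here, compound 1 thus stands at that limit, with no measured step to another compound to lean on.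

Compound 3 `Nc1nc(N)c2c(-c3ccccc3)cn([C@@H]3O[C@H](CO)[C@@H](O)[C@H]3O)c2n1` differs from compound 1 in one place: phenyl in place of thiophen-3-yl on an aromatic carbon. Within the data shown here, compound 2 also bears a phenyl on its core, on a different core than compound 1, and it too gives only a limit, so there is no measured step for this change. The step from compound 1 to compound 3 is expected to be none beyond the scatter, both remaining at the limit, a number no higher from compound 1 to compound 3 (the limit leaves the size open). Compound 3 is therefore estimated to come out near 20000 nM, within a range of 8000 nM to 50000 nM, and most probably reported again only as a limit.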

Compound 3, half-maximal inhibitory concentration: > 20000 nM
Compound 3: no number, only a limit; the forecaster's own chance of this, stated with the estimate: 85%; the middle value sits exactly at the limit.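

No step from compound 1 to compound 3 can be read, because both results are limits and not numbers: the limit of > 20000 nM in this assay, at which 3 of the 3 values shown sit.

The compounds shown leave open whether phenyl in place of thiophen-3-yl changes the activity at all, and which structures, if any, would give a numbered value in this assay.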